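The source may hold more compounds than are shown below. What is called first, only, known or untested is meant among the compounds shown, and "the series" means these compounds.

Compound 1, `COc1ccc(OC)c(/C=N/NC(=O)Nc2ccc(Oc3ccnc(-c4nncn4CCN(C)C)c3)c(F)c2)c1`, gives 1510 nM in a functional assay on MKN-45 cells (Homo sapiens) for cytotoxicity, read by MTT assay, with a stated time of 72 h; on this read-out lower numbers stand for stronger inhibition and higher numbers for weaker inhibition.
Compound 2, `CN(C)CCn1cnnc1-c1cc(Oc2ccc(NC(=O)N/N=C/c3cccc(Cl)c3Cl)cc2F)ccn1`, gives 51 nM in this assay.
Compound 3, `COc1ccc(/C=N/NC(=O)Nc2ccc(Oc3ccnc(-c4nncn4CCN(C)C)c3)c(F)c2)cc1O`, gives 2510 nM in this assay.

Compound 2 stands lowest of the three numbers in this assay. Its separation from the others is told by two steps: a 30-fold lower number from compound 1 to compound 2 (1.47 log units; beyond the scatter) and a 49-fold higher number from compound 2 to compound 3 (1.69 log units; beyond the scatter). Both are large and beyond the scatter, so compound 2 is clearly the strongest inhibitor of the three on this read-out. The two oxygen-bearing rings, by contrast, sit close together: a 1.7-fold higher number from compound 1 to compound 3 (0.22 log units; within the scatter), which is within the scatter.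

Compound 4, `COc1cc(/C=N/NC(=O)Nc2ccc(Oc3ccnc(-c4nncn4CCN(C)C)c3)c(F)c2)ccc1O`, is the next step from compound 2. The change is 4-hydroxy-3-methoxyphenyl in place of 2,3-dichlorophenyl on a carbon with a double bond to nitrogen. It is a close relative of the step to compound 3, where a hydroxy-methoxyphenyl also replaced the 2,3-dichlorophenyl and the number rose sharply. The step from compound 1 to compound 3 shows that swapping the arrangement of oxygen substituents on this ring moved the number only within the scatter. Taken together, a large upward step is expected in this assay, landing compound 4 near compounds 1 and 3.

Compound 4 is therefore estimated at 2000 nM, with a range from 800 nM to 5000 nM. That estimate means an expected step of a 39-fold higher number from compound 2 to compound 4 (1.59 log units; beyond the scatter).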

Compound 4, half-maximal inhibitory concentration: 3780 nM
For compound 4 the middle estimate is 1.9-fold (0.28 log units) below the measured one, within the range that was stated.
By their numbers in this assay, from the lowest: compound 2; then compounds 1, 3 and 4 (each within the scatter of the next, the first and the last beyond it).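

In this assay, the 4-hydroxy-3-methoxyphenyl group on a carbon with a double bond to nitrogen confirms the gap already seen for the other oxygen-bearing rings, with a 74-fold higher number from compound 2 to compound 4 (1.87 log units; beyond the scatter), so all three such rings now stand far from the 2,3-dichlorophenyl group of compound 2. Exchanging the 3-hydroxy-4-methoxyphenyl group for its 4-hydroxy-3-methoxyphenyl counterpart gives no readable difference, with a 1.5-fold higher number from compound 3 to compound 4 (0.18 log units; within the scatter), so compounds 3 and 4 cannot be told apart on this read-out. The oxygen-bearing rings do not form a single level, however: a 2.5-fold higher number from compound 1 to compound 4 (0.40 log units; beyond the scatter) is a modest step, while compound 3 lies within the scatter of both compound 1 and compound 4.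

Nothing available here accounts for why these ring changes shift the number. With 2,3-dichlorophenyl as the only chlorine-bearing ring among the compounds shown, it remains open how a single chlorine, a 3,4-dichlorophenyl group, an unsubstituted phenyl or a ring carrying an amine would fall in this assay.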